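A few compounds are considered here, and "the series" means these few. Any claim that something is new, unique, unknown or untested is made for them only; others in the source may bear on it.

Measured in a functional assay on Jurkat cells (Homo sapiens) for inhibition; a lower number here means a stronger inhibitor, a higher number a weaker inhibitor:
Compound 1 `CCOC(=O)c1cnc(NN2C(=O)C=C(C)C2=O)nc1`: 13000 nM
Compound 2 `CCOC(=O)c1cnc(NN2C(=O)C=C(C)C2=O)nc1C(F)(F)C(F)(F)F`: 200 nM
Compound 3 `CCOC(=O)c1cnc(NN2C(=O)C=C(C)C2=O)nc1-c1cccs1`: 140 nM

Compound 3 stands far under compound 1, with a 93-fold lower number from compound 1 to compound 3 (1.97 log units; beyond the scatter), and level with compound 2 within the scatter, with a 1.4-fold lower number from compound 2 to compound 3 (0.15 log units; within the scatter). The unmeasured compound 4 `CCOC(=O)c1cnc(NN2C(=O)C=C(C)C2=O)nc1-c1ccsc1` keeps the shared core and differs in one place: thiophen-3-yl in place of thiophen-2-yl on an aromatic carbon. It carries thiophen-3-yl in place of thiophen-2-yl, on the aromatic carbon ortho to the ethoxycarbonyl group.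

Going by the values given here, no measured step makes this exact exchange, so the evidence is indirect. Filling that carbon at all brought the large drops, a 65-fold lower number from compound 1 to compound 2 (1.81 log units; beyond the scatter) as well as the one to compound 3. Once the carbon was filled, exchanging one group for a quite different one gave only a 1.4-fold lower number from compound 2 to compound 3 (0.15 log units; within the scatter). On that basis, compound 4 is expected to stay close to compound 3 at 140 nM, with no step beyond the scatter in this assay. The expected step is a 1.1-fold higher number from compound 3 to compound 4 (0.03 log units; within the scatter). The estimated value for compound 4 is 150 nM, with an expected range from 70 nM to 350 nM.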

Compound 4, half-maximal inhibitory concentration: 200 nM
Estimate against measurement, compound 4: 1.3-fold (0.12 log units) below; measured number inside the range.
By their numbers in this assay, from the lowest: compounds 3, 2 and 4 (each within the scatter of the next); then compound 1.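

In this assay, exchanging thiophen-2-yl for thiophen-3-yl, the same atoms joined differently, gives a 1.4-fold higher number from compound 3 to compound 4 (0.15 log units; within the scatter) and so shows that the point of attachment of the thiophene makes no difference beyond the scatter on this aromatic carbon. The new group also gives no change at the digits printed from compound 2 to compound 4 (within the scatter) against pentafluoroethyl and a 65-fold lower number from compound 1 to compound 4 (1.81 log units; beyond the scatter) against hydrogen, which places compounds 2, 3 and 4 within the scatter of one another and all three far from compound 1. Nothing available explains this result or why filling this carbon matters.

From the compounds shown here alone, it remains open whether an amine, a carboxylic acid or a longer alkyl chain on this carbon would also stay level with these three groups. Going by these compounds, it also remains open whether a methyl or chloro substituent on the thiophene ring would separate compound 3 from compound 4.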